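Thiosemicarbazide series: ring swap on the thiocarbonyl carbon

The source may report more compounds than this note shows. Statements on the series, on what has been measured and on what is new or still open speak of the compounds shown alone.

Measured so far in a functional assay on A-375 cells (Homo sapiens) for cytotoxicity, read by MTT assay, with a stated time of 72 h, tested at 100 uM; a higher number here means more inhibition of growth at the concentration tested, a lower number less inhibition of growth:
compound 1 `Cc1ccnc(/C(N)=N/NC(=S)N2CCSCC2)c1` — 89.9%
compound 2 `N/C(=N\NC(=S)N1CCSCC1)c1ccccn1` — 87.8%
compound 3 `Cc1cccc(/C(N)=N/NC(=S)N2CCCCCC2)n1` — 80.9%

The three numbers lie close together. Compound 1 gives the upper value of the set, but the step of a number 2.1 percentage points lower from compound 1 to compound 2 (within the scatter) is within the scatter, and compound 3 with 80.9% is also within the scatter of compound 1. Nothing in this assay separates the three.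

Compound 4 `Cc1ccnc(/C(N)=N/NC(=S)N2CCCCC2)c1` is not yet measured. It differs from compound 1 by piperidin-1-yl in place of thiomorpholin-4-yl on a thiocarbonyl carbon. Within the data shown here, the only single-place step measured, from compound 1 to compound 2, concerns the methyl on the aromatic ring, not the ring on the thiocarbonyl carbon, so no measured step bears directly on this change. Compound 3 carries a different ring at that position, but it also differs in the methyl placement, so its value shows only that such a variation stays within the scatter of compound 1. No step beyond the scatter is therefore expected in this assay. Compound 4 is estimated at 86%, in the range 72% to 96%, an expected step of a number 3.9 percentage points lower from compound 1 to compound 4 (within the scatter).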

Compound 4, percent growth inhibition at one concentration: 85.6%
Compound 4: the middle estimate sits 0.4 percentage points above what was measured; low and high end bracket the measured number.
By their numbers in this assay, from the lowest: compounds 3, 4, 2 and 1 (each within the scatter of the next).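

With the rest of compound 1 unchanged, piperidin-1-yl in place of thiomorpholin-4-yl on a thiocarbonyl carbon gives in this assay a number 4.3 percentage points lower from compound 1 to compound 4 (within the scatter). Among these compounds, this is the first single-place step at this position, and it shows that the ring can go without its sulfur, and without the hydrogen-bond acceptor counted for thiomorpholin-4-yl, with no step beyond the scatter at the concentration tested. No supporting measurement is available to explain this outcome.

Still open, from the compounds shown here alone, is whether morpholin-4-yl, piperazin-1-yl or an open-chain dimethylamino group on the thiocarbonyl carbon would also stay within the scatter of compound 1. Also open, going by these compounds, is whether the same swap would read alike on the core of compound 2, which lacks the methyl.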